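A few compounds are considered here, and "the series" means these few. Any claim that something is new, unique, unknown or untested is made for them only; others in the source may bear on it.

Measured compounds:
- compound 1 `O=C([C@@H]1CCCN(S(=O)(=O)c2ccc(S(=O)(=O)N3CC[C@@H](O)C3)cc2)C1)N1CCC(F)(F)CC1` gives 210 nM in a functional assay on MIA PaCa-2 cells (Homo sapiens) for inhibition, read by MTT assay, with a stated time of 7 days; on this read-out higher numbers stand for weaker inhibition and lower numbers for stronger inhibition
- compound 2 `CCN(CC)S(=O)(=O)c1ccc(S(=O)(=O)N2CCC[C@@H](C(=O)N3CCC(OC)CC3)C2)cc1` gives 140 nM in this assay
- compound 3 `CCN(CC)S(=O)(=O)c1ccc(S(=O)(=O)N2CCC[C@@H](C(=O)N3CCC(C(F)(F)F)CC3)C2)cc1` gives 320 nM in this assay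

On these numbers compound 1 sits second highest of the three, though its distance to compound 2 and to compound 3 is each within the scatter, so no order among the three can be claimed. Compound 4 `CN(C)S(=O)(=O)c1ccc(S(=O)(=O)N2CCC[C@@H](C(=O)N3CCC(F)(F)CC3)C2)cc1` keeps the core of compound 1 and changes only the amine on the sulfonyl group: dimethylamino in place of 3-hydroxypyrrolidin-1-yl on a sulfonyl sulfur. Among the compounds with values here, none of the measured compounds differs from another at this place, so no measured step bears on it directly. Within the data shown here, the only measured step, a 2.3-fold higher number from compound 2 to compound 3 (0.36 log units; beyond the scatter), concerns a change on the amide side and is modest. Compounds 2 and 3, which both carry a dialkylamino group on the sulfonyl sulfur, give numbers close to that of compound 1. With no evidence that the sulfonyl amine matters here, the expected step of a 1.1-fold lower number from compound 1 to compound 4 (0.02 log units; within the scatter) is none beyond the scatter. Compound 4 is therefore estimated at 200 nM, with a range from 70 nM to 600 nM.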

Compound 4, half-maximal inhibitory concentration: 118 nM
Compound 4: the middle estimate sits 1.7-fold (0.23 log units) above what was measured; the range from low to high includes it.
By their numbers in this assay, from the lowest: compounds 4, 2, 1 and 3 (each within the scatter of the next, the first and the last beyond it).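

In this assay, within the data shown here, the step on the sulfonyl sulfur, with dimethylamino in place of 3-hydroxypyrrolidin-1-yl, is a 1.8-fold lower number from compound 1 to compound 4 (0.25 log units; within the scatter), and it is the first measured step at this place. The ring, its hydrogen-bond donor and its defined stereocentre can therefore all leave together without a step beyond the scatter, so on this one pair none of them is shown to be needed for the reading in this cell assay. Nothing measured here offers an explanation for this result.

The pair cannot separate the ring from its hydroxyl; the plain pyrrolidin-1-yl group would bear on that. Going by these compounds, how the number responds to amines of another kind on this sulfur, such as morpholin-4-yl or piperazin-1-yl, also stays open.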